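Chloro to methyl on the anilino ring: lipophilicity notes

The source may report more compounds than this note shows. Statements on the series, on what has been measured and on what is new or still open speak of the compounds shown alone.

Measured compounds:
compound 1 `CCOC(=O)C1=C(C)NC(=S)NC1c1cn(C(=O)CNc2ccccc2Cl)c2ccccc12` — 3.44
compound 2 `CCOC(=O)C1=C(C)NC(=O)NC1c1cn(C(=O)CNc2ccc([N+](=O)[O-])cc2Cl)c2ccccc12` — 1.99

In a physicochemical assay for lipophilicity (on this read-out higher numbers stand for higher lipophilicity and lower numbers for lower lipophilicity), compound 2 gives 1.99, the lower of the two numbers. Compound 1 gives 3.44, a gap that lies beyond the usual scatter. The two measured compounds differ in more than one place, so no single-change step can be read from them; only the two values stand side by side.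

Compound 3 `CCOC(=O)C1=C(C)NC(=O)NC1c1cn(C(=O)CNc2ccc([N+](=O)[O-])cc2C)c2ccccc12` differs from compound 2 in one place: methyl in place of chloro on an aromatic carbon. Both groups count one heavy atom, bring no ring, no donor, no acceptor and no charge, so the change is small in size. In this assay the expected change is a number 0.14 log units lower from compound 2 to compound 3 (within the scatter), a slight move toward lower lipophilicity that may well stay within the scatter rather than beyond it.

For compound 3 the value in this assay is estimated at 1.85, with a range from 1.45 to 2.25.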

Compound 3, partition coefficient: 1.94
Compound 3: middle estimate off by 0.09 log units, on the low side; measured number inside the range.
By their numbers in this assay, from the lowest: compounds 3 and 2 (each within the scatter of the next); then compound 1.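

In this assay, going from 2-chloro-4-nitrophenyl to 2-methyl-4-nitrophenyl gives a number 0.05 log units lower from compound 2 to compound 3 (within the scatter), so on this aromatic carbon, ortho to a large group and meta to a nitro group, methyl and chloro cannot be told apart on this read-out. Among the compounds shown here, this is the first step that can be read as a single change: compound 1 and compound 2 differ in more than one place, and their gap says nothing about this position or about this exchange on its own. No measurement at hand bears on why the two groups give values this close, so the result stands as an observation without an explanation.

On these data alone, whether this position stays as undiscriminating with a different kind of group on the same carbon, such as an amine, a carboxylic acid or a longer chain, remains open. Also open, as far as these compounds go, is whether methyl in place of chloro would read the same on the core of compound 1, where the surroundings of this ring differ.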